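From 1-methylpiperidin-3-yl to phenoxymethyl on the side chain

A few compounds are considered here, and "the series" means these few. Any claim that something is new, unique, unknown or untested is made for them only; others in the source may bear on it.

In a functional assay on a cell-free system (plasma, Homo sapiens) for inhibition, with Plasma (Rattus norvegicus) as the target (a lower number here means a stronger inhibitor, a higher number a weaker inhibitor), compound 1 `Cc1c(OCc2cccnc2)ccc2c(N3CCNCC3)cc(=O)oc12` gives 1420 nM, compound 2 `CSCOc1ccc2c(N3CCNCC3)cc(=O)oc2c1C` gives 3400 nM and compound 3 `Cc1c(OCC2CCCN(C)C2)ccc2c(N3CCNCC3)cc(=O)oc12` gives 16400 nM, the highest number of the three and so the weakest inhibitor here. Compound 4 `Cc1c(OCCOc2ccccc2)ccc2c(N3CCNCC3)cc(=O)oc12` keeps the shared core but carries phenoxymethyl in place of 1-methylpiperidin-3-yl on a saturated chain carbon bound to an oxygen on an aromatic ring. Both measured steps arriving at the 1-methylpiperidin-3-yl group go upward: a 12-fold higher number from compound 1 to compound 3 (1.06 log units; beyond the scatter) is large and a 4.8-fold higher number from compound 2 to compound 3 (0.68 log units; beyond the scatter) is modest. Neither involves phenoxymethyl, so only a modest fall is expected in this assay, an estimated 4.7-fold lower number from compound 3 to compound 4 (0.67 log units; beyond the scatter). Compound 4 is expected at about 3500 nM, within a range of 900 nM to 13000 nM.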

Compound 4, half-maximal inhibitory concentration: 14300 nM
The estimate for compound 4 lay 4.1-fold (0.61 log units) below the measured number; the measured number lies above the stated range.
By their numbers in this assay, from the lowest: compound 1; then compound 2; then compounds 4 and 3 (each within the scatter of the next).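

In this assay a six-membered aromatic ring on this chain is not enough to keep the number low: phenoxymethyl and 1-methylpiperidin-3-yl stand level (a 1.1-fold lower number from compound 3 to compound 4 (0.06 log units; within the scatter)). Pyridin-3-yl keeps a clear lead over phenoxymethyl (a 10-fold higher number from compound 1 to compound 4 (1.00 log units; beyond the scatter)), and methylsulfanyl keeps a smaller one (a 4.2-fold higher number from compound 2 to compound 4 (0.62 log units; beyond the scatter)). No measurement at hand explains these steps. On these data alone, whether a plain phenyl, with no oxygen in the chain, would match pyridin-3-yl or phenoxymethyl stays open, as does the effect of a carboxylic acid here.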